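This account rests on a few compounds, and the source may have more. Where it says the series, first, only, none or still open, it means among the compounds named here.

Measured compounds:
compound 1 `CCOCCCNC1=Nc2ccccc2C(C)N1`: -0.3
compound 2 `CNC1=Nc2ccccc2C(C)N1`: -0.6

Both were measured in a physicochemical assay for lipophilicity; a lower number here means a more polar compound, a higher number a more lipophilic compound. Of the two numbers, compound 1 has the highest; its nearest neighbour is compound 2, and the step of a number 0.30 log units lower from compound 1 to compound 2 (within the scatter) lies within the scatter, so the two are not separated. Compound 3 `CCCCNC1=Nc2ccccc2C(C)N1` has not yet been measured. It differs from compound 1 as follows: methyl in place of ethoxy on a saturated chain carbon, three bonds along the chain from an amine nitrogen. One hydrogen-bond acceptor leaves and none enters; read one bond further out, the difference is 3-ethoxypropyl to butyl. Among the measured compounds shown here, the only measured step, a number 0.30 log units lower from compound 1 to compound 2 (within the scatter), removes the whole 2-ethoxyethyl and bears on this change only loosely: it shows that the chain as a whole contributes little, but it does not separate the oxygen from the carbons, and no measured pair swaps an oxygen for a carbon at fixed chain length. With one acceptor leaving and a carbon entering, the number in this assay is expected to rise beyond the scatter. The expected step is a number 0.70 log units higher from compound 1 to compound 3 (beyond the scatter). Compound 3 is therefore estimated at 0.4, range -0.1 to 0.9.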

Compound 3, distribution coefficient: -0.3
Estimate against measurement, compound 3: 0.70 log units above; the measured number lies below the stated range.
By their numbers in this assay, from the lowest: compounds 2, 1 and 3 (each within the scatter of the next).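

In this assay, among the compounds shown here, the exchange of ethoxy for methyl on a saturated chain carbon, three bonds along the chain from an amine nitrogen, gives no change at the digits printed from compound 1 to compound 3 (within the scatter) and is the first measured pair that separates the oxygen from the carbons: with 3-ethoxypropyl set against butyl, the loss of the hydrogen-bond acceptor does not move the number out of the scatter. Propyl in place of hydrogen on a saturated chain carbon bound to an amine nitrogen gives a number 0.30 log units higher from compound 2 to compound 3 (within the scatter) and so a chain without oxygen also stays unseparated from the compound with the bare methyl on that nitrogen, which leaves all three substituents shown indistinguishable in this assay at this position. No supporting measurement is available to explain this flat result.

On these data alone, whether the number stays this flat with a chain longer than 3-ethoxypropyl or butyl, or with a carboxylic acid or an amine carried on the chain, remains open. How a phenyl ring at this position would read in this assay is equally open, as the compounds shown hold only open chains there.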